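Swapping the Aryl Group on a Shared Core

This account rests on a few compounds, and the source may have more. Where it says the series, first, only, none or still open, it means among the compounds named here.

Compound 1 `Cc1ccccc1-c1nc(CN2CCC(C(=O)NCCCN3CCCC(CC(C)C)C3)CC2)c(C)o1` and compound 2 `Cc1cccc(F)c1-c1nc(CN2CCC(C(=O)NCCCN3C[C@H](C)C[C@H](C)C3)CC2)c(C)o1` share one core. In an ADME assay on microsomes from liver (Rattus norvegicus) for metabolic stability, read by LC-MS, using NADPH, at 37 degrees C (on this read-out lower numbers stand for a shorter-lived compound and higher numbers for a longer-lived compound), compound 1 gives 0.0383 h and compound 2 gives 0.0733 h, the higher of the two numbers, yet within the usual scatter of compound 1, so neither can be called the longer-lived. Compound 3 `Cc1cc(C)cc(-c2nc(CN3CCC(C(=O)NCCCN4C[C@H](C)C[C@H](C)C4)CC3)c(C)o2)c1` differs from compound 2 in one place: 3,5-dimethylphenyl in place of 2-fluoro-6-methylphenyl on an aromatic carbon. Among the measured compounds shown here, no measured pair shows what such a change does here, so the expected step is a 1.2-fold lower number from compound 2 to compound 3 (0.09 log units; within the scatter), no shift beyond the scatter. Compound 3 is therefore estimated at 0.06 h, with a range from 0.025 h to 0.15 h.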

Compound 3, half-life: < 0.5 h
Compound 3 gave a limit, no number; the forecaster's own chance of this, stated with the estimate: 5%; the middle value is on the limit's open side.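

Compound 3 gave a limit rather than a number, so no step from compound 2 to compound 3 can be read: the limit of < 0.5 h in this assay, at which 1 of the 3 values shown sits.

The compounds shown leave open whether 3,5-dimethylphenyl in place of 2-fluoro-6-methylphenyl shortens or lengthens the half-life.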